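A few compounds are considered here, and "the series" means these few. Any claim that something is new, unique, unknown or untested is made for them only; others in the source may bear on it.

In a functional assay on the whole organism with Rattus norvegicus as the target, at a dose of 100 mg/kg (on this read-out higher numbers stand for more inhibition at the one dose given (going by the name of the read-out) and lower numbers for less inhibition), three compounds have been measured so far. Compound 1 `CC/N=C(\S)NCCCCCn1nc(-c2ccccc2)ccc1=O` gives 66.4%, compound 2 `C/N=C(/NC#N)NCCCCn1nc(-c2ccc(C)cc2)ccc1=O` gives 45.7%, and compound 3 `C/N=C(/NC#N)NCCCn1nc(C)ccc1=O` gives 6.8%. Compound 2 thus stands second highest of the three, beyond the scatter on both sides: below compound 1 and well above compound 3. Compound 4 `C/N=C(/NC#N)NCCCCn1nc(C)ccc1=O` has not yet been measured; it differs from compound 2 in one place: methyl in place of 4-methylphenyl on an aromatic carbon. Compound 3 carries the same methyl group and gives a far lower number than compound 2, though its chain also differs, so no exact step can be read from it. A sizeable fall beyond the scatter is expected, a number 30.7 percentage points lower from compound 2 to compound 4 (beyond the scatter). Compound 4 is therefore estimated at 15%, within 0% to 40%.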

Compound 4, a percentage reported as inhibition, in the whole organism at one dose (the size of the read-out at that dose, not a potency): 23.5%
Compound 4: the middle estimate sits 8.5 percentage points below what was measured; low and high end bracket the measured number.
By their numbers in this assay, from the lowest: compound 3; then compound 4; then compound 2; then compound 1.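

In this assay, putting methyl in place of 4-methylphenyl on this aromatic carbon gives a number 22.2 percentage points lower from compound 2 to compound 4 (beyond the scatter) with the chain and the rest of the molecule unchanged. Going by these compounds alone, this ties a loss of inhibition at this dose to this one position, which the earlier compounds could not do. No measurement here gives a cause for the fall.

Open, as far as these compounds go, is whether an unsubstituted phenyl, a 4-methoxyphenyl or an amine on this carbon would give a number nearer compound 2 or compound 4. Also open, from the compounds shown here alone, is whether the same change would give a similar step on a pentyl chain.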